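The source may hold more compounds than are shown below. What is called first, only, known or untested is meant among the compounds shown, and "the series" means these compounds.

Compound 1 `O=C(Nc1cccc(-n2cc(-c3ccncc3)c(-c3cc(O)cc(Cl)c3)n2)c1)Nc1ccc(Cl)c(C(F)(F)F)c1` and compound 2 `COc1cc(Cl)cc(-c2nn(-c3cccc(NC(=O)Nc4ccc(Cl)c(C(F)(F)F)c4)c3)cc2-c2ccncc2)c1` share one core; compound 3 `O=C(Nc1cccc(-n2cc(-c3ccncc3)c(-c3cc(O)cc(Cl)c3)n2)c1)c1cc(C(F)(F)F)cc(C(F)(F)F)c1` and compound 4 `COc1cc(Cl)cc(-c2nn(-c3cccc(NC(=O)c4cc(C(F)(F)F)cc(C(F)(F)F)c4)c3)cc2-c2ccncc2)c1` share another. The difference between the two cores is not broken down here. In a functional assay on 786-0 cells (Homo sapiens) for inhibition, read by sulforhodamine B assay, with a stated time of 48 h, tested at 10 uM (on this read-out higher numbers stand for a weaker effect at the one concentration tested and lower numbers for a stronger effect), compound 1 gives -29.8%, and compound 2 gives -4.76%. The change that separates them, (methyl in place of hydrogen on an oxygen on an aromatic ring), made a step of a number 25 percentage points higher from compound 1 to compound 2 (beyond the scatter). Compound 3, in this assay, gives 55.2%, the highest of the three numbers, so its starting point lies well above that of compound 1.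

The change from compound 3 to compound 4 is methyl in place of hydrogen on an oxygen on an aromatic ring, the same change as before, occurring twice among these compounds. The expectation for compound 4 rests on a single measured instance of this change, the step from compound 1 to compound 2 of a number 25 percentage points higher from compound 1 to compound 2 (beyond the scatter), so an estimated step of similar size, a number 22.8 percentage points higher from compound 3 to compound 4 (beyond the scatter), is applied to compound 3. Compound 4 is therefore expected to give about 78% in this assay, most likely between 62% and 95%.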

Compound 4, a percentage reported as activity, at one concentration (the size of the read-out at that concentration, not a potency): 80.2%
The estimate for compound 4 lay 2.2 percentage points below the measured number; the measured number falls inside the stated range.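

Replacing hydroxy with methoxy on the 3-chloro-5-hydroxyphenyl group gave a number 25 percentage points higher from compound 3 to compound 4 (beyond the scatter) in this assay, and the size of this step matched the one seen on the other core: the same change on two cores in this assay, a number 25 percentage points higher (beyond the scatter) from compound 1 to compound 2 and a number 25 percentage points higher (beyond the scatter) from compound 3 to compound 4, 0 percentage points apart, within the scatter of two such steps

Within these two pairs, then, the change carried over from the core of compound 1 to the core of compound 3 with its size intact, so the step measured on one core would have served as a guide to the other. Among these compounds, this rests on only two pairs, tested at one concentration in one cell assay, and it shows neither that the same step would appear on a further core or in another assay nor why adding the methyl raises the number.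

The compounds shown leave open whether a longer chain on that oxygen, such as ethyl, or an amine in place of the hydroxy would shift the number in the same way. They also leave open how much the difference between the two cores contributes on its own.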